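This account rests on a few compounds, and the source may have more. Where it says the series, first, only, none or still open, it means among the compounds named here.

In a functional assay on PC-3 cells (Homo sapiens) for cytotoxicity (a lower number here means that less compound is needed, a higher number that more compound is needed for the effect), three compounds that share a core and differ in the aromatic group on the double-bonded chain have been measured. Compound 1 `COC1=C(C)C(=O)/C(=C(O)/C=C/c2ccc(OC)cc2)C(=O)C1(C)C` gives 18.2 ug/mL, compound 2 `COC1=C(C)C(=O)/C(=C(O)/C=C/c2ccc(C)cc2)C(=O)C1(C)C` gives 8.2 ug/mL, and compound 3 `COC1=C(C)C(=O)/C(=C(O)/C=C/c2cc(C)cc(C)c2)C(=O)C1(C)C` gives 8.8 ug/mL. Compound 3 therefore groups with compound 2, and both lie below compound 1. The relevant steps are a 1.1-fold higher number from compound 2 to compound 3 (0.03 log units; within the scatter) and a 2.1-fold lower number from compound 1 to compound 3 (0.32 log units; beyond the scatter).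

The next compound, compound 4 `COC1=C(C)C(=O)/C(=C(O)/C=C/c2cccs2)C(=O)C1(C)C`, has not yet been measured, and the change leading to it is thiophen-2-yl in place of 3,5-dimethylphenyl on a double-bonded chain carbon bound to a double-bonded chain carbon. Within the data shown here, no measured compound carries thiophen-2-yl, so the known steps bear on it only indirectly. Among the three aromatic groups measured, the largest step, a 2.2-fold lower number from compound 1 to compound 2 (0.35 log units; beyond the scatter), is modest. Compound 4 is therefore expected to stay close to compound 3 at 8.8 ug/mL, with no step beyond the scatter in this assay in either direction. The expected change is a 1.1-fold higher number from compound 3 to compound 4 (0.06 log units; within the scatter). For compound 4 the estimated value is 10 ug/mL, within an expected range of 5 ug/mL to 20 ug/mL.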

Compound 4, concentration for half-maximal effect: 18.2 ug/mL
Estimate against measurement, compound 4: 1.8-fold (0.26 log units) below; measured number inside the range.
By their numbers in this assay, from the lowest: compounds 2 and 3 (each within the scatter of the next); then compounds 1 and 4 (each within the scatter of the next).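

In this assay the exchange of 3,5-dimethylphenyl for thiophen-2-yl on the double-bonded chain carbon gives a clear rise (a 2.1-fold higher number from compound 3 to compound 4 (0.32 log units; beyond the scatter)), and the exchange of 4-methylphenyl for thiophen-2-yl gives a step of like size (a 2.2-fold higher number from compound 2 to compound 4 (0.35 log units; beyond the scatter)). This place therefore responds to a change of the aromatic ring itself, not only to the groups that ring carries. Against 4-methoxyphenyl, thiophen-2-yl makes no difference (no change at the digits printed from compound 1 to compound 4 (within the scatter)), so the four compounds form two pairs, with the two methyl-bearing groups in the lower pair.

Going by these compounds, whether a furan-2-yl or a pyridin-3-yl group at this place would join the lower or the upper pair stays open, as does the effect of a methyl group on the thiophen-2-yl ring. Nothing available here accounts for the gap between the two pairs.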